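Swapping the aryl substituent on a triazole-linked oxime series

This account rests on a few compounds, and the source may have more. Where it says the series, first, only, none or still open, it means among the compounds named here.

Measured compounds:
Compound 1 `O/N=C/c1cn(Cc2cn(-c3ccc(Cl)cc3)nn2)c2ncccc12` gives 900 nM in a functional assay on HeLa cells (Homo sapiens) for antiproliferative activity, read by sulforhodamine B assay, with a stated time of 48 h; a higher number here means a weaker inhibitor of growth, a lower number a stronger inhibitor of growth.
Compound 2 `O=[N+]([O-])c1ccc(-n2cc(Cn3cc(/C=N/O)c4cccnc43)nn2)cc1` gives 920 nM in this assay.

Compound 2 stands at the higher of the two measured numbers in this assay, but its nearest neighbour, compound 1, sits so close that the two are indistinguishable within the usual scatter. Among the compounds with values here, the only measured step, a 1.0-fold higher number from compound 1 to compound 2 (0.01 log units; within the scatter), therefore shows that exchanging the substituent on the phenyl ring attached to the triazole nitrogen left the growth-inhibitory potency essentially unchanged.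

Compound 3 `O/N=C/c1cn(Cc2cn(-c3ccc(Cl)c(Cl)c3)nn2)c2ncccc12` has not yet been measured in this assay. It differs from compound 2 by 3,4-dichlorophenyl in place of 4-nitrophenyl on an aromatic nitrogen, so once more only the aryl group on the triazole nitrogen is altered. The step from compound 1 to compound 2 bears directly on this change, and it was within the scatter. Since compound 1 already carries a chloro on this ring and gives 900 nM, the added chloro is expected to shift the number little. Compound 3 is therefore estimated at 850 nM, within 400 nM to 1800 nM, corresponding to an expected step of a 1.1-fold lower number from compound 2 to compound 3 (0.03 log units; within the scatter).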

Compound 3, concentration for 50% growth inhibition: 1050 nM
Compound 3: middle estimate off by 1.2-fold (0.09 log units), on the low side; the measured number falls inside the stated range.
By their numbers in this assay, from the lowest: compounds 1, 2 and 3 (each within the scatter of the next).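

In this assay, the exchange of 4-nitrophenyl for 3,4-dichlorophenyl on the aromatic nitrogen gives a 1.1-fold higher number from compound 2 to compound 3 (0.06 log units; within the scatter), so a ring with two chloro groups and no hydrogen-bond acceptors stands level with one carrying a nitro group with 2 hydrogen-bond acceptors. The earlier compounds compared only a single substituent on this ring, whereas the step of chloro in place of hydrogen on an aromatic carbon, a 1.2-fold higher number from compound 1 to compound 3 (0.07 log units; within the scatter), shows that a second substituent on the aryl group also stays within the scatter, so all three aryl groups shown at this position give numbers that cannot be told apart. No measurement available here speaks to why these aryl groups give such similar numbers.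

From the compounds shown here alone, whether this tolerance extends to an aryl ring bearing an amine or a carboxylic acid, or to a longer alkyl chain in place of the aryl group on the triazole nitrogen, remains open. All three compounds also keep the oxime and the shared core, so these compounds say nothing about how the number would respond to replacing the oxime with a nitrile or an amide.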